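The source may hold more compounds than are shown below. What is called first, only, known or untested is meant among the compounds shown, and "the series" means these compounds.

Measured compounds:
- compound 1 `C/C(=C\C#N)N[C@@H]1c2cc(C#N)ccc2OC(C)(C)[C@H]1O`, which in a functional assay (Trachealis) for inhibition, with Cavia porcellus as the target (a higher number here means a weaker inhibitor, a lower number a stronger inhibitor), gives 1230 nM
- compound 2 `CC1(C)C=C(n2cccc2[N+](=O)[O-])c2cc(C#N)ccc2O1`, which in this assay gives 690 nM
- compound 3 `CC1(C)Oc2ccc(C#N)cc2[C@@H](n2cccc2C(=O)C(F)(F)F)[C@@H]1O`, for which this assay reports only a limit, > 20000 nM

The numbers of compound 2 and compound 1 lie within the usual scatter of each other, so neither can be set above the other. Compound 3 gives only a limit of the assay and no number.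

Compound 4 `CC1(C)C=C(n2cccc2C(=O)C(F)(F)F)c2cc(C#N)ccc2O1` is not yet measured. It differs from compound 2 by (trifluoromethyl)carbonyl in place of nitro on an aromatic carbon; in words, (trifluoromethyl)carbonyl in place of nitro on an aromatic carbon. For the measured compounds named here, no measured pair shows this change on a shared core, so no measured step can be drawn on. Compound 3 carries the same (trifluoromethyl)carbonyl group on a different core, and it sits at the limit of > 20000 nM in this assay, at which 1 of the 3 values shown sits.

For compound 4 a weakening step from compound 2 is expected, a 7.2-fold higher number from compound 2 to compound 4 (0.86 log units; beyond the scatter), well beyond the scatter. Because compound 3 reaches (the limit of > 20000 nM in this assay, at which 1 of the 3 values shown sits), the chance that compound 4 also returns only a limit is taken as real. Compound 4 is therefore estimated at 5000 nM in this assay. The expected range for compound 4 runs from 1000 nM to 20000 nM.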

Compound 4, half-maximal inhibitory concentration: 690 nM
Beside the measured number, compound 4's estimate is 7.2-fold (0.86 log units) above it; measured number outside the range, below it.
By their numbers in this assay, from the lowest: compounds 2, 4 and 1 (each within the scatter of the next). At a limit, above all of these: compound 3.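

Putting (trifluoromethyl)carbonyl in place of nitro on an aromatic carbon gives, in this assay, no change at the digits printed from compound 2 to compound 4 (within the scatter). On the shared core of compound 2 and compound 4, the place next to the ring nitrogen therefore takes a group of 6 heavy atoms instead of one of 3, and 1 hydrogen-bond acceptor instead of 2, with no change that can be read. This also shows that (trifluoromethyl)carbonyl does not by itself go with a limit, since compound 3, which carries the same group on a different core, reports a limit of the assay and no number: the limit of > 20000 nM in this assay, at which 1 of the 4 values shown sits.

The compounds shown leave open whether the limit of compound 3 belongs to its core or to the group on that core. They also leave open whether an amine, a carboxylic acid or a longer chain at this place on the shared core would leave the number where it stands, since only nitro and (trifluoromethyl)carbonyl can be compared here.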